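From Triazolyl to Piperazinyl Side Group

This account rests on a few compounds, and the source may have more. Where it says the series, first, only, none or still open, it means among the compounds named here.

Values in a functional assay on MCF7 cells (Homo sapiens) for cytotoxicity, read by MTT assay, with a stated time of 72 h; a higher number here means a weaker inhibitor, a lower number a stronger inhibitor:
- compound 1 `O=C1c2c[n+]([O-])c3ccccc3c2C(=O)c2c1c1ccccc1n2CCCCn1ccnc1`: 130 nM
- compound 2 `O=C1c2c[n+]([O-])c3ccccc3c2C(=O)c2c1c1ccccc1n2Cc1cn(CC(O)CO)nn1`: 1110 nM

Of these two, compound 2 has the higher number at 1110 nM, which makes it the weaker inhibitor. Compound 3 `O=C1c2c[n+]([O-])c3ccccc3c2C(=O)c2c1c1ccccc1n2CCCCN1CCNCC1` has not yet been measured. Its structure differs from that of compound 2 as follows: 3-(piperazin-1-yl)propyl in place of 1-(2,3-dihydroxypropyl)-1H-1,2,3-triazol-4-yl on a saturated chain carbon bound to an aromatic nitrogen. In words, 3-(piperazin-1-yl)propyl takes the place of 1-(2,3-dihydroxypropyl)-1H-1,2,3-triazol-4-yl on a saturated chain carbon bound to an aromatic nitrogen.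

Going by the values given here, one measured step bears on this: an 8.5-fold higher number from compound 1 to compound 2 (0.93 log units; beyond the scatter). That step brought in the same triazolyl group in place of 3-(1H-imidazol-1-yl)propyl. The new change removes this group again, but the incoming ring is a different one, so a single step is only a rough guide. In this assay the expected change is a drop of similar size, a 5.0-fold lower number from compound 2 to compound 3 (0.70 log units; beyond the scatter). Compound 3 is estimated at 220 nM, with an expected range of 60 nM to 800 nM.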

Compound 3, half-maximal inhibitory concentration: 12000 nM
For compound 3 the middle estimate is 55-fold (1.74 log units) below the measured one; measured number outside the range, above it.
By their numbers in this assay, from the lowest: compound 1; then compound 2; then compound 3.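

In this assay, the ring at the end of the chain turns out to matter far more than the first pair could show: with the chain itself kept, piperazin-1-yl in place of 1H-imidazol-1-yl gives a 92-fold higher number from compound 1 to compound 3 (1.97 log units; beyond the scatter) and is the largest step seen so far. Leaving the triazolyl side group can also go either way, as the change to 3-(piperazin-1-yl)propyl gives an 11-fold higher number from compound 2 to compound 3 (1.03 log units; beyond the scatter), which puts compound 2 in the middle rather than at the weak end of the series. Nothing measured here accounts for these differences.

As far as these compounds go, it remains open whether a morpholin-4-yl ring or a simple dimethylamino group at the end of the same chain would land nearer compound 1 or compound 3. The effect of a longer chain carrying piperazin-1-yl is also still unknown.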